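This account rests on a few compounds, and the source may have more. Where it says the series, first, only, none or still open, it means among the compounds named here.

The series shares the core shown by compound 1 `C=CC1=C(C(=O)NCc2ccc(Cl)cc2)C(c2ccc(OC)c(OC)c2)OC1`, with compound 2 `C=CC1=C(C(=O)NCc2ccc(Cl)cc2)C(c2ccc(OC)cc2)OC1` and compound 3 `C=CC1=C(C(=O)Nc2ccccc2OC)C(c2ccc(F)cc2)OC1` carrying other groups at its edges. In a functional assay on HeLa cells (Homo sapiens) for cytotoxicity, read by MTT assay, with a stated time of 24 h (a lower number here means a stronger inhibitor, a higher number a weaker inhibitor), compound 1 gives > 100000 nM, which is a limit of the assay rather than a number. Compound 2 gives > 100000 nM in this assay, again a limit. Compound 3 likewise gives > 100000 nM in this assay, also a limit. The step that the two limits leave unreadable from compound 1 to compound 2 is therefore not readable, as both ends are limits; the limit of > 100000 nM in this assay, at which 3 of the 3 values shown sit, summarises where every value sits. Compound 2 thus stands at the limit, with no number of its own to anchor it. Compound 4 `C=CC1=C(C(=O)NC2CCCCC2)C(c2ccc(OC)cc2)OC1` differs from compound 2 by one change: cyclohexyl in place of 4-chlorobenzyl on an amide-type nitrogen. For the measured compounds named here, no measured step touches the amide-type nitrogen, and the single measured step, a step that the two limits leave unreadable from compound 1 to compound 2, is itself unreadable, so no size or direction can be drawn from it. Given (the limit of > 100000 nM in this assay, at which 3 of the 3 values shown sit), compound 4 is expected to return to the limit again, and the step that the limit leaves unreadable from compound 2 to compound 4 is expected to be nothing readable. Compound 4 is estimated at 150000 nM, with a range from 50000 nM to 500000 nM.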

Compound 4, half-maximal inhibitory concentration: 24800 nM
Compound 4: the middle estimate sits 6.0-fold (0.78 log units) above what was measured, outside the stated range (below it).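

In this assay, for the compounds shown here, the amide-type nitrogen is the first place where a change gives a readable result: cyclohexyl in place of 4-chlorobenzyl gives an at least 4.0-fold lower number from compound 2 to compound 4 (0.60 log units; beyond the scatter). Compound 2 carries a limit and not a number, so this step fixes only a minimum size and leaves its full size unknown. Compound 4 is the only compound shown that has a number of its own, which places the first measurable activity with a non-aromatic ring on this nitrogen, while the other compounds remain at the limit: the limit of > 100000 nM in this assay, at which 3 of the 4 values shown sit.

The compounds shown leave open whether a cyclopentyl ring, an open hexyl chain or a plain benzyl group on this nitrogen would also give a measurable value. They also leave open whether cyclohexyl gives one when the core carries the aromatic groups of compound 1 or compound 3.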